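Chloro for Fluoro Carried from One Core to Another

The source may hold more compounds than are shown below. What is called first, only, known or untested is meant among the compounds shown, and "the series" means these compounds.

Compound 1 `CC(C)=CCC/C(C)=C/CC/C(C)=C/CC[C@@H]1[C@@]2(C)CC/C(=N\OCc3cn(-c4ccc(F)cc4)nn3)C(C)(C)[C@@H]2CC[C@@]1(C)O` and compound 2 `CC(C)=CCC/C(C)=C/CC/C(C)=C/CC[C@@H]1[C@@]2(C)CC/C(=N\OCc3cn(-c4ccc(Cl)cc4)nn3)C(C)(C)[C@@H]2CC[C@@]1(C)O` share one core; compound 3 `CC(C)=CCC/C(C)=C/CC/C(C)=C/CC[C@@H]1[C@@]2(C)C/C(=C\c3ccc(OCc4cn(-c5ccc(F)cc5)nn4)cc3)C(=O)C(C)(C)[C@@H]2CC[C@@]1(C)O` and compound 4 `CC(C)=CCC/C(C)=C/CC/C(C)=C/CC[C@@H]1[C@@]2(C)C/C(=C\c3ccc(OCc4cn(-c5ccc(Cl)cc5)nn4)cc3)C(=O)C(C)(C)[C@@H]2CC[C@@]1(C)O` share another, and the difference between the two cores is not broken down here. In a functional assay on MCF7 cells (Homo sapiens) for cytotoxicity, read by MTT assay, with a stated time of 48 h (on this read-out lower numbers stand for stronger inhibition and higher numbers for weaker inhibition), compound 1 gives 26000 nM and compound 2 gives 12400 nM, so the change chloro in place of fluoro on an aromatic carbon brought a 2.1-fold lower number from compound 1 to compound 2 (0.32 log units; beyond the scatter). In this assay compound 3 gives 42000 nM, a number close to that of compound 1 and apart from that of compound 2. Compound 4 carries the same change on the other core, (chloro in place of fluoro on an aromatic carbon), at an identical place. Because the first step of a 2.1-fold lower number from compound 1 to compound 2 (0.32 log units; beyond the scatter) was modest but beyond the scatter, a step of about the same size is expected here. Compound 4 is therefore estimated at 20000 nM, within 10000 nM to 45000 nM. That estimate means an expected 2.1-fold lower number from compound 3 to compound 4 (0.32 log units; beyond the scatter).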

Compound 4, half-maximal inhibitory concentration: 72400 nM
Compound 4: middle estimate off by 3.6-fold (0.56 log units), on the low side; measured number above the stated range.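

On the core of compound 3, chloro in place of fluoro gave a 1.7-fold higher number from compound 3 to compound 4 (0.24 log units; within the scatter), so compound 3 and compound 4 cannot be told apart in this assay. The lower number seen on the core of compound 1 did not carry over, and the two steps differ: the same change on two cores in this assay, a 2.1-fold lower number (0.32 log units; beyond the scatter) from compound 1 to compound 2 and a 1.7-fold higher number (0.24 log units; within the scatter) from compound 3 to compound 4, 3.6-fold (0.56 log units) apart, beyond the scatter of two such steps

This does not show why the cores respond differently, nor does it show a true reversal on the second core, whose step stays within the scatter. The compounds shown leave open whether a bromo or a methyl group at the same place would behave alike on both cores. Which part of the difference between the two cores matters also remains open.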